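The compounds below may be only part of what the source reports. "The series", "measured", "known", "first", "only" and "open" are said of these compounds alone.

Working notes on the series. Three compounds have so far been run in a functional assay on thoracic aorta (Rattus norvegicus, strain Wistar), with a stated time of 15 min; on this read-out higher numbers stand for an effect only at larger amounts of compound and lower numbers for an effect already at smaller amounts. Compound 2 `COc1ccc(Br)cc1C(C)NC(=O)N(C)S(=O)(=O)c1ccccc1` serves as the reference point; in this assay compound 2 gives 16800 nM. Compound 1 `CC(C)Oc1ccc(Br)cc1C(C)NC(=O)N(C)S(=O)(=O)c1ccccc1` differs from compound 2 only by isopropyl in place of methyl on an oxygen on an aromatic ring, and in this assay compound 1 gives 32100 nM, so that the step is a 1.9-fold higher number from compound 2 to compound 1 (0.28 log units; within the scatter). Compound 3 `COc1ccc(Br)cc1C(C)NC(=O)N(C)S(=O)(=O)c1ccc(Cl)cc1` differs from compound 2 by chloro in place of hydrogen on an aromatic carbon, and in this assay compound 3 gives 19100 nM, a step of a 1.1-fold higher number from compound 2 to compound 3 (0.06 log units; within the scatter). Compound 1 and compound 3 are not joined by a single change; their two values lie within the scatter of each other, so no order between them is claimed.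

Compound 4 `CC(C)Oc1ccc(Br)cc1C(C)NC(=O)N(C)S(=O)(=O)c1ccc(Cl)cc1` has not yet been measured. It differs from compound 3 by isopropyl in place of methyl on an oxygen on an aromatic ring. This is the same change that turns compound 2 into compound 1, made here on the core of compound 3, which differs from the core of compound 2 by chloro in place of hydrogen on an aromatic carbon. The place of the change is described in the same words in both pairs, so it is taken as the same change. The step expected from compound 3 to compound 4 is a 1.9-fold higher number from compound 3 to compound 4 (0.28 log units; within the scatter), set beside the earlier one because a 1.9-fold higher number from compound 2 to compound 1 (0.28 log units; within the scatter) was itself within the scatter and gives no reason to expect a larger shift on the second core. Compound 4 is accordingly estimated in this assay at 36000 nM, with the expected range running from 15000 nM to 85000 nM.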

Compound 4, half-maximal effective concentration: 43200 nM
Compound 4: middle estimate off by 1.2-fold (0.08 log units), on the low side, within the range that was stated.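

In this assay, isopropyl in place of methyl on an oxygen on an aromatic ring gives a 2.3-fold higher number from compound 3 to compound 4 (0.35 log units; beyond the scatter), and this step agrees with the one seen on the other core: the same change on two cores in this assay, a 1.9-fold higher number (0.28 log units; within the scatter) from compound 2 to compound 1 and a 2.3-fold higher number (0.35 log units; beyond the scatter) from compound 3 to compound 4, 1.2-fold (0.07 log units) apart, within the scatter of two such steps Chloro in place of hydrogen on an aromatic carbon, read in the same set of compounds, gives a 1.3-fold higher number from compound 1 to compound 4 (0.13 log units; within the scatter), and it too carries over between cores: the same change on two cores in this assay, a 1.1-fold higher number (0.06 log units; within the scatter) from compound 2 to compound 3 and a 1.3-fold higher number (0.13 log units; within the scatter) from compound 1 to compound 4, 1.2-fold (0.07 log units) apart, within the scatter of two such steps The two changes therefore behave as much the same steps on these cores, and the fact that one isopropyl step lies within the scatter and the other beyond it marks no real difference between them; this rests on four compounds forming a single square in one assay, however, and shows nothing about transfer to any other core.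

As far as these compounds go, whether the same steps hold on a core carrying a different group in place of the shared ones remains open, as does what a longer chain would do in place of isopropyl on that oxygen. From the compounds shown here alone, it is also open how an amine or a carboxylic acid in place of chloro would read in this assay.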